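Sulfonamide series: hydroxy for ethyl on the sulfonyl aryl

The source may hold more compounds than are shown below. What is called first, only, known or untested is meant among the compounds shown, and "the series" means these compounds.

The series shares one core, seen in compound 1 `O=S(=O)(Nc1ccc(-c2nc3ccccc3o2)cc1)c1ccc(Cl)s1`, compound 2 `O=S(=O)(Nc1ccc2oc(-c3ccccc3)nc2c1)c1ccc(Cl)c(C(F)(F)F)c1` and compound 3 `CCc1ccc(S(=O)(=O)Nc2ccc(-c3nc4ccccc4o3)cc2)cc1`. In an ADME assay on HEK293 cells (Homo sapiens) for cytotoxicity, read by resazurin assay, with a stated time of 48 h (a lower number here means that less compound is tolerated, a higher number that more compound is tolerated), compound 1 reports only a limit, > 100000 nM, that limit being (the limit of > 100000 nM in this assay, at which 1 of the 3 values shown sits). In this assay compound 2 gives 66000 nM and compound 3 gives 82000 nM, the highest of the two numbers, with compound 2 within the scatter of it. The measured step of an at least 1.2-fold lower number from compound 1 to compound 3 (0.08 log units; that floor lies within the scatter) shows no change beyond the scatter. Compound 4 `O=S(=O)(Nc1ccc(-c2nc3ccccc3o2)cc1)c1ccc(O)cc1` differs from compound 3 by hydroxy in place of ethyl on an aromatic carbon. Within the data shown here, no measured step covers this change; the one measured step is flat. Compound 4 is therefore expected to stay near compound 3, an estimated step of a 1.1-fold higher number from compound 3 to compound 4 (0.04 log units; within the scatter). The estimated value for compound 4 is 90000 nM, range 40000 nM to 200000 nM.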

Compound 4, half-maximal cytotoxic concentration: > 100000 nM
Compound 4 ended at the assay's limit; the forecaster's own chance of this, stated with the estimate: 40%; middle value at least 1.1-fold (0.04 log units) away from the limit.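

Hydroxy in place of ethyl on the aromatic carbon para to a large group gives in this assay an at least 1.2-fold higher number from compound 3 to compound 4 (0.08 log units; that floor lies within the scatter) and so shows no step beyond the scatter, even with a hydrogen-bond donor and acceptor entering. Compound 4 reports only a limit, > 100000 nM, and joins compound 1 there: the limit of > 100000 nM in this assay, at which 2 of the 4 values shown sit. The step between these two limits cannot be read. Open, on these data alone, is whether an amine, a carboxylic acid or a longer chain at this place would give a readable number. As far as these compounds go, how far compound 4 lies past its limit also stays open.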